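A few compounds are considered here, and "the series" means these few. Any claim that something is new, unique, unknown or untested is made for them only; others in the source may bear on it.

Measured in an assay on isolated protein (strain Sprague-Dawley) for inhibition of Amine oxidase [flavin-containing] B (Rattus norvegicus), read by spectrophotometry, with a stated time of 5 min; on this read-out higher numbers stand for weaker inhibition and lower numbers for stronger inhibition:
compound 1 `CN(C)C(=O)COc1cc(=O)oc2cc(OCc3cccc(Cl)c3)ccc12` gives 501 nM
compound 2 `O=c1cc(Cl)c2ccc(OCc3cccc(Cl)c3)cc2o1` gives 20.9 nM
compound 3 `CNc1cc(=O)oc2cc(OCc3cccc(Cl)c3)ccc12` gives 8.71 nM

Compound 3 holds the lowest number of the three in this assay. The nearest neighbour is compound 2, separated by a 2.4-fold lower number from compound 2 to compound 3 (0.38 log units; beyond the scatter). The furthest is compound 1, separated by a 58-fold lower number from compound 1 to compound 3 (1.76 log units; beyond the scatter), and the same large substituent also separates compound 1 from compound 2 by a 24-fold lower number from compound 1 to compound 2 (1.38 log units; beyond the scatter). Both small substituents on this position therefore sit well below the large one, with methylamino a modest step ahead of chloro.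

Compound 4 `N#Cc1cc(=O)oc2cc(OCc3cccc(Cl)c3)ccc12` differs from compound 3 by cyano in place of methylamino on an aromatic carbon. Among the compounds with values here, no cyano analogue has been measured in this assay, so the change has no direct precedent here. The step that bears on it most closely is a 2.4-fold lower number from compound 2 to compound 3 (0.38 log units; beyond the scatter), which shows that moving away from methylamino to another small substituent gives a modest rise in the number; the large steps from compound 1 are tied to a much bulkier group and are not expected to apply. A modest increase in this assay, toward the value of compound 2, is expected, with the outcome near either neighbour plausible.

Compound 4 is therefore estimated at 25 nM, with a range from 6 nM to 100 nM. This estimate corresponds to a 2.9-fold higher number from compound 3 to compound 4 (0.46 log units; beyond the scatter).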

Compound 4, half-maximal inhibitory concentration: 102 nM
Compound 4: the middle estimate sits 4.1-fold (0.61 log units) below what was measured; the measured number lies above the stated range.
By their numbers in this assay, from the lowest: compound 3; then compound 2; then compound 4; then compound 1.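

In this assay, a small group on this carbon does not by itself give a low number: methylamino and cyano have the same count of heavy atoms, yet the change gives a 12-fold higher number from compound 3 to compound 4 (1.07 log units; beyond the scatter), and the comparison with chloro gives a 4.9-fold higher number from compound 2 to compound 4 (0.69 log units; beyond the scatter). The earlier picture of small groups sitting close together and well below (dimethylcarbamoyl)methoxy therefore does not hold for cyano, which shows only a 4.9-fold lower number from compound 1 to compound 4 (0.69 log units; beyond the scatter) and lies partway between the large group and the other two small ones. Methylamino brings a hydrogen-bond donor that cyano lacks, but no measurement bears on why the number rises at this change.

Compounds carrying amino, dimethylamino or methoxy on this aromatic carbon would show whether the gap follows the hydrogen-bond donor or some other difference between methylamino and cyano. On these data alone, it also remains open whether the order of methylamino, chloro and cyano would hold with a different substituent elsewhere on the shared core.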